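This account rests on a few compounds, and the source may have more. Where it says the series, first, only, none or still open, it means among the compounds named here.

Working notes on a set of four compounds characterised in a physicochemical assay for lipophilicity, read by HPLC; a lower number here means a more polar compound, a higher number a more lipophilic compound. Compound 1 `CCn1c(-c2cnc(C)nc2)nc2c(O[C@H]3CCN(C(=O)C4CC4)C3)ncnc21` gives 1 in this assay. Compound 2 `CCC(=O)N1CC[C@H](Oc2ncnc3c2nc(-c2cnc(C)nc2)n3CC)C1` gives 0.8, and compound 3 `CCC(=O)N1CC[C@H](Nc2ncnc3c2nc(-c2cnc(C)nc2)n3CC)C1` gives 0.7; all three numbers sit within the scatter of one another. Compound 4 `CCn1c(-c2cnc(C)nc2)nc2c(N[C@H]3CCN(C(=O)C4CC4)C3)ncnc21` has not yet been measured in this assay.

Compound 2 and compound 1 share a core and differ by cyclopropyl in place of ethyl on a carbonyl carbon, a change that gave a number 0.20 log units higher from compound 2 to compound 1 (within the scatter). The same change separates compound 3 from compound 4: cyclopropyl in place of ethyl on a carbonyl carbon. The cores of compound 3 and compound 2 differ, but the difference between the two cores is not broken down here.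

The expectation for compound 4 rests on the measured pair compound 2 and compound 1, whose step was a number 0.20 log units higher from compound 2 to compound 1 (within the scatter), carried over to compound 3 as far as a step within the scatter can be carried over. For compound 4 the expected step is a number 0.20 log units higher from compound 3 to compound 4 (within the scatter). Compound 4 is therefore estimated at 0.9 in this assay, with a likely range from 0.6 to 1.2.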

Compound 4, distribution coefficient: 0.8
Compound 4: middle estimate off by 0.10 log units, on the high side; the range from low to high includes it.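

In this assay the swap of ethyl for cyclopropyl on a carbonyl carbon gives a number 0.10 log units higher from compound 3 to compound 4 (within the scatter) on one core, and on the other core the same swap gives a number 0.20 log units higher from compound 2 to compound 1 (within the scatter) in the same assay. What carries over is therefore limited: on both cores, propanoyl to cyclopropylcarbonyl leaves the pair within the scatter, which shows neither a real shift from this change nor any real dependence of the step on the core. Nothing available here accounts for these numbers.

The compounds shown hold only ethyl and cyclopropyl on this carbonyl carbon, so the result for a longer chain, an amine or a carboxylic acid in that place remains open. Within the data shown here, with only two cores represented, it also remains open whether the same swap would stay within the scatter on a third core.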